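Inverting one ring stereocentre in a pyrrolidine-type amide

The compounds below may be only part of what the source reports. "The series", "measured", "known", "first", "only" and "open" are said of these compounds alone.

Measured so far:
- compound 1, `CC(C)C[C@H](NC(=O)[C@]1(Cc2ccccc2)CCN1C(=O)OCc1ccccc1)C(N)=O`: 50000 nM
- compound 2, `C[C@H](NC(=O)[C@]1(Cc2ccccc2)CCN1C(=O)OCc1ccccc1)C(=O)NCc1ccccc1`: 42000 nM

In an ADME assay on HELF cells (Homo sapiens) for cytotoxicity, with a stated time of 3 days (a lower number here means that less compound is tolerated, a higher number that more compound is tolerated), compound 1 gives 50000 nM, the highest of the two numbers, though its neighbour compound 2 sits only a 1.2-fold lower number from compound 1 to compound 2 (0.08 log units; within the scatter) away, a gap that lies within the scatter. That single measured step swaps the group on the amide-type nitrogen and leaves the ring untouched.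

Compound 3, `CC(C)C[C@H](NC(=O)[C@@]1(Cc2ccccc2)CCN1C(=O)OCc1ccccc1)C(N)=O`, has not yet been tested in this assay. Compared with compound 1 it changes nothing in its atoms or bonds: the two compounds have the same atoms and bonds and differ only in configuration as drawn: 1 of 2 stereo elements differ; a stereocentre at a saturated ring carbon is drawn S in compound 1 and R in compound 3.

Among the compounds with values here, no measured step here touches a stereocentre, so nothing in the two values speaks directly to this change. Within the data shown here, the one step available, from compound 1 to compound 2, stayed within the scatter despite altering a whole side group, and the two numbers are close to each other. On that basis the expectation for compound 3 is a step of no change at the digits printed from compound 1 to compound 3 (within the scatter), which is to say no change beyond the scatter. Compound 3 is therefore estimated at 50000 nM, within a range from 20000 nM to 100000 nM.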

Compound 3, half-maximal cytotoxic concentration: 66000 nM
Beside the measured number, compound 3's estimate is 1.3-fold (0.12 log units) below it; measured number inside the range.
By their numbers in this assay, from the lowest: compounds 2, 1 and 3 (each within the scatter of the next).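

In this assay, within the data shown here, inverting the stereocentre at the saturated ring carbon gives a 1.3-fold higher number from compound 1 to compound 3 (0.12 log units; within the scatter) and so provides the first measured step at this position. The comparison is a clean one, because nothing else separates the two compounds: the fact that compounds 1 and 3 differ only in the configuration as drawn. With the 1-carbamoyl-3-methylbutyl group held in place, the drawn configuration at this ring carbon therefore makes no difference that can be told apart from the scatter of this cell assay, so the S and R forms cannot be ranked by tolerance here.

The inversion has been read with only one side group, so the compounds shown leave open whether it would be just as silent with the 1-(benzylcarbamoyl)ethyl group of compound 2, which appears here only with the ring carbon drawn S. They also leave open whether the configuration would begin to matter with a free amine or a carboxylic acid in place of the 1-carbamoyl-3-methylbutyl group, since every compound shown carries a neutral amide in that part of the molecule.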